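A few compounds are considered here, and "the series" means these few. Any claim that something is new, unique, unknown or untested is made for them only; others in the source may bear on it.

Compound 2 `Brc1ccc(-c2cn3ccnc3c(-c3ccc4ncn(C5CCCCC5)c4c3)n2)cc1` gives 32.1% in a functional assay on RPMI-8226 cells (Homo sapiens) for inhibition, read by sulforhodamine B assay, with a stated time of 48 h, tested at 10 uM (on this read-out higher numbers stand for more inhibition at the one concentration tested (going by the name of the read-out) and lower numbers for less inhibition), the higher of the two numbers measured, while compound 1 `Brc1cn2ccnc2c(-c2ccc3ncn(C4CCCCC4)c3c2)n1` gives 14.9%. Compound 3 `COc1ccccc1-c1cn2ccnc2c(-c2ccc3ncn(C4CCCCC4)c3c2)n1` carries 2-methoxyphenyl in place of 4-bromophenyl on an aromatic carbon. Within the data shown here, the only measured step, a number 17.2 percentage points higher from compound 1 to compound 2 (beyond the scatter), swapped a lone bromine for an entire aromatic ring; the move from compound 2 to compound 3 keeps an aromatic ring and changes only what sits on it, so no measured step bears on it directly. The estimate for compound 3 is therefore 28%, within 8% to 50%, an expected step of a number 4.1 percentage points lower from compound 2 to compound 3 (within the scatter) that should stay within the scatter.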

Compound 3, a percentage reported as inhibition, at one concentration (the size of the read-out at that concentration, not a potency): 35.9%
Compound 3: middle estimate off by 7.9 percentage points, on the low side, and the stated range covers the measured number.
By their numbers in this assay, from the lowest: compound 1; then compounds 2 and 3 (each within the scatter of the next).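

Exchanging 4-bromophenyl for 2-methoxyphenyl gives a number 3.8 percentage points higher from compound 2 to compound 3 (within the scatter), so at this position the ring's substituent and its place on the ring can both change without a reading beyond the scatter. Set against the lone bromine, the second aryl group also gives a number 21 percentage points higher from compound 1 to compound 3 (beyond the scatter), so the gain seen with compound 2 is not unique to 4-bromophenyl. No available evidence explains these readings.

Still open, as far as these compounds go, is how a ring carrying an amine or a carboxylic acid would read here. The separate contributions of the substituent's identity and its place on the ring also remain unresolved, as these changed together.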